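Piperidinyl replaces iodophenylamino on a fused four-ring core

The compounds below may be only part of what the source reports. "The series", "measured", "known", "first", "only" and "open" are said of these compounds alone.

In a functional assay on MCF7 cells (Homo sapiens) for inhibition, read by sulforhodamine B assay (a lower number here means a stronger inhibitor, a higher number a weaker inhibitor), compound 1 `O=C1C=C(Nc2ccc(I)cc2)C(=O)c2c1nc1n2[C@H]2OC[C@@H](O)[C@H]2OC1` gives 2230 nM, the lowest of the two numbers at hand, while compound 2 `Cc1ccc(NC2=CC(=O)c3c(nc4n3[C@H]3OC[C@@H](O)[C@H]3OC4)C2=O)cc1C` gives 4950 nM, a gap beyond the usual scatter. Compound 3 `O=C1C=C(N2CCCCC2)C(=O)c2c1nc1n2[C@H]2OC[C@@H](O)[C@H]2OC1` differs from compound 1 in one place: piperidin-1-yl in place of (4-iodophenyl)amino on a double-bonded ring carbon. Within the data shown here, no measured pair shows this exchange, so its size is unknown. The expectation is a moderate move toward a weaker inhibitor, the step from a 3.1-fold higher number from compound 1 to compound 3 (0.50 log units; beyond the scatter) being larger than the scatter. Compound 3 is therefore estimated at 7000 nM, with a range from 2000 nM to 25000 nM.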

Compound 3, half-maximal inhibitory concentration: > 8000 nM
Compound 3 ended at the assay's limit (the forecaster's own chance of this, stated with the estimate: 10%); middle value at least 1.1-fold (0.05 log units) away from the limit.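

In this assay, among these compounds, piperidin-1-yl in place of (4-iodophenyl)amino on this double-bonded ring carbon gives an at least 3.5-fold higher number from compound 1 to compound 3 (0.55 log units; beyond the scatter), the first reading of a change at this position. Compound 3 stands at a limit of the assay and not at a number, so the step gives only a lower bound: the limit of > 8000 nM in this assay, at which 1 of the 3 values shown sits. The change removes the aromatic ring and the hydrogen-bond donor together, and this single step cannot separate them.

The compounds shown leave open how a cyclohexylamino group, which keeps only the donor, or a methyl(phenyl)amino group, which keeps only the aromatic ring, would read at this carbon.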